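The source may report more compounds than this note shows. Statements on the series, on what has been measured and on what is new or still open speak of the compounds shown alone.

Series notes. Compound 1 `CCN(c1ccc(C#N)c(Cl)c1)c1cc(-c2ccco2)ccc1C` is the reference point. In a functional assay on CWR22R cells (Homo sapiens) for antiproliferative activity, read by CCK-8 assay, with a stated time of 6 days (a higher number here means a weaker inhibitor, a lower number a stronger inhibitor), compound 1 gives only a limit, > 30000 nM, and not a number. This is the limit of > 30000 nM in this assay, at which 1 of the 3 values shown sits. Within the data shown here, compound 3 `N#Cc1ccc(N2CCc3cc(-c4cnc5ccccc5c4)ccc3C2)cc1C(F)(F)F` is the one member with a measured figure; in this assay compound 3 gives 25900 nM. Compound 2 `Cc1noc(C)c1-c1cccc2c1CCCN2c1ccc(C#N)c(C(F)(F)F)c1` is built on another scaffold; in this assay compound 2 gives "not determined" (no result reported). Among the measured compounds shown here, no step between measured compounds is available, so compound 1 is placed only by its limit, with the figure of compound 3 the sole numeric point alongside it, and a ranking of the two is not possible.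

Compound 4 `CCN(c1ccc(C#N)c(Cl)c1)c1cc(-c2ccoc2)ccc1C` is the unmeasured analogue of compound 1. The change is furan-3-yl in place of furan-2-yl on an aromatic carbon. None of the measured compounds bears on this change, and no cause for any effect of it can be drawn from the data. Because compound 1 shows only the limit > 30000 nM, compound 4 is expected to remain weak. The expected step of a number no higher from compound 1 to compound 4 (the limit leaves the size open) is none beyond the scatter. In this assay compound 4 is estimated at 30000 nM, with a range from 15000 nM to 60000 nM, and a further limit rather than a number is the likelier report.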

Compound 4, half-maximal inhibitory concentration: > 30000 nM
Compound 4: only a limit was reported (the forecaster's own chance of this, stated with the estimate: 60%); the middle value sits exactly at the limit.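

No step can be read between compound 1 and compound 4, since both are reported only as a limit and not as a number: the limit of > 30000 nM in this assay, at which 2 of the 4 values shown sit.

The compounds shown leave open whether furan-3-yl in place of furan-2-yl on an aromatic carbon has any effect in this assay.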